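Ring-nitrogen substituent swap: compound 3 to compound 4

The source may hold more compounds than are shown below. What is called first, only, known or untested is meant among the compounds shown, and "the series" means these compounds.

Measured so far:
compound 1, `CC(C)N1CCN(Cc2csc(N)c2C(=O)c2ccc(Cl)cc2)CC1`: -7.4%
compound 2, `Nc1scc(CN2CCN(c3ccc(F)cc3Cl)CC2)c1C(=O)c1ccc(Cl)cc1`: -70%
compound 3, `Nc1scc(CN2CCN(c3cccnc3)CC2)c1C(=O)c1ccc(Cl)cc1`: -23%

In a functional assay on CHO cells with adenosine receptor A1 (Homo sapiens) as the target, read by cAMP accumulation and immunoassay, with a stated time of 6 min, tested at 10 uM (on this read-out lower numbers stand for a stronger effect and higher numbers for a weaker effect at the one concentration tested), compound 3 stands second highest of the three: the step of a number 15.6 percentage points lower from compound 1 to compound 3 (beyond the scatter) sets it under compound 1, while a number 47 percentage points higher from compound 2 to compound 3 (beyond the scatter) sets it well over compound 2.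

Compound 4, `Nc1scc(CN2CCN(c3cccc(F)c3)CC2)c1C(=O)c1ccc(Cl)cc1`, differs by 3-fluorophenyl in place of pyridin-3-yl on an amine nitrogen in a ring. Among the measured compounds shown here, the steps that bear on this are a number 62.6 percentage points lower from compound 1 to compound 2 (beyond the scatter), a large lowering when 2-chloro-4-fluorophenyl replaced isopropyl, and a number 15.6 percentage points lower from compound 1 to compound 3 (beyond the scatter), a modest one for pyridin-3-yl. A 3-fluorophenyl on the same ring nitrogen is expected to move the number down beyond the scatter, less far than compound 2 went, so a number 22 percentage points lower from compound 3 to compound 4 (beyond the scatter) is expected. Compound 4 is thus estimated at -45%, within -75% to -15%.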

Compound 4, a percentage reported as activity, at one concentration (the size of the read-out at that concentration, not a potency): -82%
For compound 4 the middle estimate is 37 percentage points above the measured one; measured number below the stated range.
By their numbers in this assay, from the lowest: compound 4; then compound 2; then compound 3; then compound 1.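

In this assay the choice between two aromatic rings on this amine nitrogen carries a large effect: 3-fluorophenyl in place of pyridin-3-yl gives a number 59 percentage points lower from compound 3 to compound 4 (beyond the scatter) and so reaches nearly as far as the whole change from isopropyl, which gives a number 74.6 percentage points lower from compound 1 to compound 4 (beyond the scatter) here. Nor does this position need the 2-chloro-4-fluorophenyl group for the lowest number of the series, since the 3-fluorophenyl group gives a number 12 percentage points lower from compound 2 to compound 4 (beyond the scatter) in its place. Nothing available here accounts for these steps.

Open, from the compounds shown here alone, is whether the step from compound 3 follows the fluorine or the carbon-only ring. A plain phenyl on the same nitrogen would separate the two.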